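Replacement of the pyrazole side arm by a hydroxycyclohexenyl group

The source may hold more compounds than are shown below. What is called first, only, known or untested is meant among the compounds shown, and "the series" means these compounds.

Within the data shown here, compound 3, `C[C@@H](O[C@H]1CN2C(=O)C=C(c3cnn(Cc4ccccc4)c3)CC2[C@@H]1c1ccc(F)cc1)c1cc(C(F)(F)F)cc(C(F)(F)F)c1`, gives 1.9 nM in an assay on CHO cells for displacement of a labelled ligand from Substance-P receptor (Homo sapiens) (a lower number here means a stronger inhibitor, a higher number a weaker inhibitor), the highest of the three numbers measured so far. Its nearest neighbour is compound 2, `C[C@@H](O[C@H]1CN2C(=O)C=C(c3ccc(C#N)cc3)CC2[C@@H]1c1ccc(F)cc1)c1cc(C(F)(F)F)cc(C(F)(F)F)c1`, which gives 1.8 nM; the step of a 1.1-fold higher number from compound 2 to compound 3 (0.02 log units; within the scatter) lies within the scatter. Compound 1, `C[C@@H](O[C@H]1CN2C(=O)C=C(c3ccccc3)CC2[C@@H]1c1ccc(F)cc1)c1cc(C(F)(F)F)cc(C(F)(F)F)c1`, gives 0.93 nM, and the step of a 2.0-fold higher number from compound 1 to compound 3 (0.31 log units; beyond the scatter) is a modest one beyond the scatter. The remaining step, a 1.9-fold higher number from compound 1 to compound 2 (0.29 log units; within the scatter), is also within the scatter.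

Compound 4, `C[C@@H](O[C@H]1CN2C(=O)C=C(C3=CCC(O)CC3)CC2[C@@H]1c1ccc(F)cc1)c1cc(C(F)(F)F)cc(C(F)(F)F)c1`, carries the change (4-hydroxycyclohex-1-en-1-yl in place of 1-benzyl-1H-pyrazol-4-yl on a double-bonded ring carbon). Among the measured compounds shown here, the measured steps all concern exchanges at this same ring carbon, and none exceeds a modest size, but every group tried so far has been aromatic; no measured step replaces an aromatic group with a non-aromatic ring bearing a hydroxyl. The expectation is therefore a modest move in this assay toward a higher number, with wide uncertainty. Compound 4 is estimated at 4.5 nM, in the range 1.5 nM to 14 nM. This expected step is a 2.4-fold higher number from compound 3 to compound 4 (0.37 log units; beyond the scatter).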

Compound 4, half-maximal inhibitory concentration: 0.18 nM
Compound 4: the middle estimate sits 25-fold (1.40 log units) above what was measured; measured number below the stated range.
By their numbers in this assay, from the lowest: compound 4; then compounds 1, 2 and 3 (each within the scatter of the next, the first and the last beyond it).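

In this assay, this ring carbon accepts a non-aromatic ring bearing a hydroxyl, and 4-hydroxycyclohex-1-en-1-yl gives a lower number than each aromatic group shown here: 1-benzyl-1H-pyrazol-4-yl (an 11-fold lower number from compound 3 to compound 4 (1.02 log units; beyond the scatter)), 4-cyanophenyl (a 10-fold lower number from compound 2 to compound 4 (1.00 log units; beyond the scatter)) and phenyl (a 5.2-fold lower number from compound 1 to compound 4 (0.71 log units; beyond the scatter)). Among the earlier compounds, exchanges at this carbon moved the number only slightly, so aromatic replacements alone gave no sign of a step as large as the first of these. Nothing available accounts for the lower number of compound 4.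

The compounds shown leave open whether the drop belongs to the hydroxyl or to the non-aromatic ring itself. Plain cyclohex-1-en-1-yl, or a cyclohexenyl ring carrying an amine in place of the hydroxyl, would help separate the two.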